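Moving a Chloro Group: Expected Cytotoxicity of Compound 3

A few compounds are considered here, and "the series" means these few. Any claim that something is new, unique, unknown or untested is made for them only; others in the source may bear on it.

Measured compounds:
compound 1, `COc1ccccc1S(=O)(=O)/C=C/c1ccccn1`, 100%
compound 2, `COc1ccccc1S(=O)(=O)/C=C/c1cccc(Cl)n1`, 100%

The study follows a small series sharing the core of compound 1. In an ADME assay on BV-2 cells (Mus musculus) for cytotoxicity, with a stated time of 24 h, tested at 10 uM (a lower number here means a stronger effect, a higher number a weaker effect of the compound at the concentration tested), compound 1 gives 100%. In the same assay compound 2 gives 100%. Compound 1 stands level with compound 2 at the digits shown, its nearest neighbour, and the step of no change at the digits printed from compound 1 to compound 2 (within the scatter) lies within the scatter, so the chloro in place of hydrogen on an aromatic carbon left the read-out untouched.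

Compound 3, `COc1ccccc1S(=O)(=O)/C=C/c1ccc(Cl)cn1`, has not yet been measured. It differs from compound 1 by chloro in place of hydrogen on an aromatic carbon. Among the measured compounds shown here, the one measured step that bears on this change is no change at the digits printed from compound 1 to compound 2 (within the scatter): it was also a chloro entering for hydrogen on the same ring, at another place, and it brought no shift beyond the scatter. On that basis the step of no change at the digits printed from compound 1 to compound 3 (within the scatter) is expected to be none beyond the scatter. Compound 3 is therefore estimated to give 100% in this assay, with a range from 88% to 108%, pending the measurement.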

Compound 3, a percentage reported as activity, at one concentration (the size of the read-out at that concentration, not a potency): 100%
Compound 3: middle estimate and measured number agree at the digits printed; low and high end bracket the measured number.
By their numbers in this assay, from the lowest: compounds 1, 2 and 3 (each within the scatter of the next).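

In this assay, chloro on this aromatic carbon, two atoms from the ring nitrogen and para to a large group, gives no change at the digits printed from compound 1 to compound 3 (within the scatter), so a second place on the ring now shows the same change leaving the read-out without a shift beyond the scatter. With compound 2 at 100% and compound 3 at 100%, the read-out at this single concentration does not tell the two chloro placements apart, which one chloro compound alone could not show. Nothing measured here bears on why the read-out stays level across these changes.

The compounds shown carry only chloro as a new group on this ring, so it remains open whether an amine, a carboxylic acid or a longer chain on this same aromatic carbon would leave the read-out equally level. Also open is whether chloro at the other free carbons of the ring would behave in the same way, and whether any of these compounds would separate from the others at a concentration other than the one tested.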